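Swapping Phenoxy for Dimethylamino on a Cytotoxicity Series

This account rests on a few compounds, and the source may have more. Where it says the series, first, only, none or still open, it means among the compounds named here.

Measured so far:
- Compound 1, `COc1cc(C)cc(-c2c(-c3ccnc(-c4ccc(C(C)=O)cc4)c3)cnn2CC#N)c1`: 81%
- Compound 2, `Cc1cc(O)cc(-c2nn(CC#N)cc2-c2ccnc(-c3ccc(Oc4ccccc4)cc3)c2)c1`: 108%

Of the compounds shown here, two have been tested in a functional assay on HOP-62 cells (Homo sapiens) for cytotoxicity, read by sulforhodamine B assay, with a stated time of 48 h, tested at 0.01 uM; on this read-out higher numbers stand for a weaker effect at the one concentration tested and lower numbers for a stronger effect. Compound 1 gives 81%. Compound 2 gives 108%, which is the higher of the two numbers, and the gap to compound 1 lies beyond the usual scatter. The two compounds differ in more than one place, so nothing can be drawn from that gap about any single change.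

The next compound, compound 3, `Cc1cc(O)cc(-c2nn(CC#N)cc2-c2ccnc(-c3ccc(N(C)C)cc3)c2)c1`, is still to be measured in this assay. It differs from compound 2 in one place: dimethylamino in place of phenoxy on an aromatic carbon.

Among the measured compounds shown here, no pair of measured compounds that differ in only one place is available, so the size of such a step has to be guessed. The expectation here is a small step, if any: because compound 2 already gives 108%, a number that shows little effect at this concentration, the step from compound 2 to compound 3 is expected to be a number 8 percentage points lower from compound 2 to compound 3 (within the scatter), not beyond the scatter. Compound 3 is therefore estimated to give 100%, with a range from 80% to 115%.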

Compound 3, a percentage reported as activity, at one concentration (the size of the read-out at that concentration, not a potency): 89%
The estimate for compound 3 lay 11 percentage points above the measured number; low and high end bracket the measured number.
By their numbers in this assay, from the lowest: compounds 1 and 3 (each within the scatter of the next); then compound 2.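

In this assay, among the compounds shown here, the change at this position gives a number 19 percentage points lower from compound 2 to compound 3 (beyond the scatter), the first measured change confined to a single place, and it shows that the group on this aromatic carbon, para to a large group, can alter the read-out on its own. Dimethylamino is a smaller group than phenoxy and has no ring, while the hydrogen-bond donor and acceptor counts stay the same, so the swap changes the size of the group and removes a ring without altering those counts. Nothing available explains why the number moves in this direction.

These two compounds cannot separate the loss of the ring from the exchange of oxygen for nitrogen, and groups such as methoxy, which keeps the oxygen without a ring, or anilino, which keeps a ring and brings a nitrogen, would pull those two changes apart. As far as these compounds go, it also remains open whether the same swap would give a similar step on a compound with different groups elsewhere, or at other concentrations, since this read-out comes from a single concentration and is not a potency.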